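The source may hold more compounds than are shown below. What is called first, only, known or untested is meant among the compounds shown, and "the series" means these compounds.

In a physicochemical assay for solubility (on this read-out higher numbers stand for higher solubility and lower numbers for lower solubility), compound 3 `CC(C)COc1cc(C(F)(F)F)nn1-c1ccc(S(C)(=O)=O)cn1` gives 50 ug/mL and compound 2 `CS(=O)(=O)c1ccc(-n2nc(C(F)(F)F)cc2NC2CCCC2)nc1` gives 25 ug/mL while compound 1 `CC1CCCN(c2cc(C(F)(F)F)nn2-c2ccc(S(C)(=O)=O)cn2)C1` has "not determined" (no result reported) as its entry. Only these two numbers exist, and the step between them is a 2.0-fold higher number from compound 2 to compound 3 (0.30 log units; within the scatter) for isobutoxy in place of cyclopentylamino on an aromatic carbon. Compound 4 `CS(=O)(=O)c1ccc(-n2nc(C(F)(F)F)cc2OCC2CCC2)nc1` differs from compound 3 by cyclobutyl in place of isopropyl on a saturated chain carbon bound to an oxygen on an aromatic ring and so carries cyclobutylmethoxy in place of isobutoxy. Going by the values given here, no measured step covers this exchange, and the one step available, a 2.0-fold higher number from compound 2 to compound 3 (0.30 log units; within the scatter) for a different exchange, offers only a loose guide. No step beyond the scatter is therefore expected, and the estimated move is a 1.4-fold lower number from compound 3 to compound 4 (0.15 log units; within the scatter) in this comparison. The estimate for compound 4 is 35 ug/mL with 12 ug/mL to 80 ug/mL as the expected range around it.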

Compound 4, solubility: 100 ug/mL
For compound 4 the middle estimate is 2.9-fold (0.46 log units) below the measured one; the whole stated range lies below it.
By their numbers in this assay, from the lowest: compounds 2, 3 and 4 (each within the scatter of the next, the first and the last beyond it).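

In this assay, cyclobutyl in place of isopropyl on a saturated chain carbon bound to an oxygen on an aromatic ring gives a 2.0-fold higher number from compound 3 to compound 4 (0.30 log units; within the scatter), so this exchange does not separate the two ethers. A wider exchange of the whole group gives a 4.0-fold higher number from compound 2 to compound 4 (0.60 log units; beyond the scatter), the only step shown that lies beyond the scatter, though it is modest. No measurement shown here accounts for either step. The compounds shown leave open how a longer chain or a terminal amine at this place would read in this assay. They also cannot divide the larger step between the change of linking atom and the change of ring.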